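Mirror Image of a Cyclopropyl Pyridine Nicotinic Ligand

This account rests on a few compounds, and the source may have more. Where it says the series, first, only, none or still open, it means among the compounds named here.

Three compounds have been characterised in an assay on a protein complex for displacement of a labelled ligand from Neuronal acetylcholine receptor; alpha2/beta2 (Rattus norvegicus), read by scintillation counting; on this read-out lower numbers stand for stronger inhibition and higher numbers for weaker inhibition. Compound 1 `c1cncc(N2CC3CC2CN3)c1` gives 0.3 nM in this assay. Compound 2 `COCC[C@H]1C[C@@H]1c1cncc(N2CCCNCC2)c1` gives 0.3 nM. Compound 3 `CN1CCCN(c2cncc(-c3cc(CCO)no3)c2)CC1` gives 46.3 nM. On these numbers compound 2 stands level with compound 1 at the digits shown, the two together being the lowest of the three values, and the gap from compound 1 to compound 2 lies within the scatter. Compound 3 sits far higher, and its distance from compound 2 lies well beyond the scatter.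

Compound 4 `COCC[C@@H]1C[C@H]1c1cncc(N2CCCNCC2)c1` is the next compound to be measured in this assay. It differs from compound 2 as follows: the two compounds have the same atoms and bonds and differ only in configuration as drawn: 2 of 2 stereo elements differ (all stereocentres are inverted: mirror images); a stereocentre at a saturated ring carbon is drawn R in compound 2 and S in compound 4; a stereocentre at a saturated ring carbon is drawn S in compound 2 and R in compound 4.

Among the measured compounds shown here, no pair among the measured compounds differs only in configuration, so the data give no direct guide to the size of such a step. In general, inverting both stereocentres of a rigid ring can leave affinity unchanged or lower it by a modest to considerable amount. Compound 4 is expected to give 1.5 nM in this assay, within a range of 0.3 nM to 15 nM. The step this estimate implies is a 5.0-fold higher number from compound 2 to compound 4 (0.70 log units; beyond the scatter), expected to be a weakening that reaches beyond the scatter but stays far short of the level seen for compound 3.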

Compound 4, inhibition constant: 0.3 nM
Estimate against measurement, compound 4: 5.0-fold (0.70 log units) above; the range from low to high includes it.
By their numbers in this assay, from the lowest: compounds 1, 2 and 4 (each within the scatter of the next); then compound 3.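

Inverting both stereocentres at the saturated ring carbons gives, in this assay, no change at the digits printed from compound 2 to compound 4 (within the scatter). This is the first direct reading of configuration among these compounds, since the earlier ones offered no pair that differed in this way alone. At this position, the two mirror images cannot be told apart at the digits printed, so in this assay the absolute configuration of this pair has no visible bearing on the read-out, and the step can be assigned to configuration alone for one reason: the fact that compounds 2 and 4 differ only in the configuration as drawn.

This holds only for the pair as drawn, with both stereocentres inverted together, and the compounds shown leave open how a form with just one of the two stereocentres inverted would behave. From the compounds shown here alone, it is also open whether the mirror images would stay level in this assay if a longer chain or a carboxylic acid stood in place of the methoxyethyl chain, or whether they would stay level on other nicotinic receptor subtypes.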